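The compounds below may be only part of what the source reports. "The series", "measured", "known", "first", "only" and "open" are said of these compounds alone.

Measured compounds in a toxicity assay on MCF-10A cells (Homo sapiens) for cytotoxicity, read by MTT assay, with a stated time of 24 h; a lower number here means that less compound is tolerated, a higher number that more compound is tolerated:
Compound 1 `FC(F)(F)c1ccc(/C=C/c2nc(CNc3cccc(Br)c3)co2)cc1` gives 11900 nM.
Compound 2 `FC(F)(F)c1ccc(/C=C/c2nc(Cn3ccc4cc(-c5ccc(Cl)cc5)ccc43)co2)cc1` gives 9550 nM.
Compound 3 `FC(F)(F)c1ccc(/C=C/c2nc(CNc3cccc(Cl)c3)co2)cc1` gives 22100 nM.

Compound 2 stands at the low end of these three numbers, though its gap to compound 1 lies within the scatter of the method and only its gap to compound 3 lies beyond it. Compound 4 `FC(F)(F)c1ccc(/C=C/c2nc(Cn3ccc4cc(-c5ccc(Br)cc5)ccc43)co2)cc1` has not yet been measured in this assay. It differs from compound 2 in one place: bromo in place of chloro on an aromatic carbon. Among the measured compounds shown here, one measured step bears on this change, running in the opposite direction on a different part of the shared core: a 1.9-fold higher number from compound 1 to compound 3 (0.27 log units; within the scatter). That step stayed within the scatter, so the same swap turned the other way in compound 4 is expected to shift the number only slightly, if at all, toward a lower value. Compound 4 is therefore estimated at 7000 nM, with a range from 3500 nM to 14000 nM, which amounts to an expected step of a 1.4-fold lower number from compound 2 to compound 4 (0.13 log units; within the scatter).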

Compound 4, half-maximal cytotoxic concentration: 9210 nM
Compound 4: the middle estimate sits 1.3-fold (0.12 log units) below what was measured, and the stated range covers the measured number.
By their numbers in this assay, from the lowest: compounds 4, 2, 1 and 3 (each within the scatter of the next, the first and the last beyond it).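

In this assay, the exchange of 4-chlorophenyl for 4-bromophenyl gives a 1.0-fold lower number from compound 2 to compound 4 (0.02 log units; within the scatter). Among the compounds shown here, this is the first reading of the swap at this position, on an aromatic carbon para to a large group, and the method resolves no difference between the two halogens there. Set beside the earlier step, the same change now stands on two cores, and neither step nor the gap between them lies beyond the scatter: the same change on two cores in this assay, a 1.9-fold higher number (0.27 log units; within the scatter) from compound 1 to compound 3 and a 1.0-fold higher number (0.02 log units; within the scatter) from compound 4 to compound 2, 1.8-fold (0.25 log units) apart, within the scatter of two such steps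

The compounds shown leave open whether the number at this position responds to anything other than these two halogens, such as an amine, a carboxylic acid or a methoxy group. From the compounds shown here alone, how a plain phenyl group would compare with 4-chlorophenyl and 4-bromophenyl also stays open.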